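The source may report more compounds than this note shows. Statements on the series, on what has been measured and on what is new or still open speak of the compounds shown alone.

Three ureas sharing one core differ only in the aryl group on an aromatic nitrogen: compound 1 `Cc1ccccc1-n1cc(COc2cccc(NC(=O)Nc3ccc(Cl)c(C(F)(F)F)c3)c2)nn1`, compound 2 `COc1ccc(-n2cc(COc3cccc(NC(=O)Nc4ccc(Cl)c(C(F)(F)F)c4)c3)nn2)cc1` and compound 3 `N#Cc1cccc(-n2cc(COc3cccc(NC(=O)Nc4ccc(Cl)c(C(F)(F)F)c4)c3)nn2)c1`. In a functional assay on HepG2 cells (Homo sapiens) for inhibition, read by MTT assay, with a stated time of 72 h (on this read-out lower numbers stand for stronger inhibition and higher numbers for weaker inhibition), compound 1 gives 3440 nM, compound 2 gives 4680 nM and compound 3 gives 2760 nM. Compound 3 sits at the lowest number of the three, yet a 1.2-fold lower number from compound 1 to compound 3 (0.10 log units; within the scatter) and a 1.7-fold lower number from compound 2 to compound 3 (0.23 log units; within the scatter) both stay within the scatter, as does a 1.4-fold higher number from compound 1 to compound 2 (0.13 log units; within the scatter). Compound 4 `CCc1cccc(-n2cc(COc3cccc(NC(=O)Nc4ccc(Cl)c(C(F)(F)F)c4)c3)nn2)c1` carries the change (ethyl in place of cyano on an aromatic carbon). The three measured steps on this same aryl ring all bear on it and none left the scatter, so no step beyond the scatter is expected in this assay. Compound 4 is therefore estimated at 3000 nM, between 1500 nM and 6000 nM, an expected step of a 1.1-fold higher number from compound 3 to compound 4 (0.04 log units; within the scatter).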

Compound 4, half-maximal inhibitory concentration: 37900 nM
Compound 4: the middle estimate sits 13-fold (1.10 log units) below what was measured; the measured number lies above the stated range.
By their numbers in this assay, from the lowest: compounds 3, 1 and 2 (each within the scatter of the next); then compound 4.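

In this assay, for the compounds shown here, the aryl ring proves sensitive after all: ethyl in place of cyano on an aromatic carbon gives a 14-fold higher number from compound 3 to compound 4 (1.14 log units; beyond the scatter), the first step beyond the scatter. The 3-ethylphenyl group also stands apart from the other two aryl groups, with an 11-fold higher number from compound 1 to compound 4 (1.04 log units; beyond the scatter) and with an 8.1-fold higher number from compound 2 to compound 4 (0.91 log units; beyond the scatter). No supporting measurement bears on why this change has so large an effect.

On these data alone, whether a methyl, a chlorine or an amine in place of the ethyl would keep the lower numbers remains open. So does whether a longer chain would move the number further.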